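Fluoro for Methoxy in a Cell Cytotoxicity Series

This account rests on a few compounds, and the source may have more. Where it says the series, first, only, none or still open, it means among the compounds named here.

Compound 1 `COc1ccc2c(/C=C(\C#N)C(=O)c3c[nH]c4cc(F)ccc34)c[nH]c2c1` gives 5500 nM in a functional assay on A549 cells (Homo sapiens) for cytotoxicity, read by WST assay, with a stated time of 48 h; a lower number here means a stronger inhibitor, a higher number a weaker inhibitor. Compound 2 `N#C/C(=C\c1c[nH]c2cc(F)ccc12)C(=O)c1c[nH]c2cc(F)ccc12` differs from it by fluoro in place of methoxy on an aromatic carbon, and in this assay compound 2 gives 36100 nM; that change produced a 6.6-fold higher number from compound 1 to compound 2 (0.82 log units; beyond the scatter). Compound 3 `COc1ccc(Cn2cc(/C=C(\C#N)C(=O)c3c[nH]c4cc(OC)ccc34)c3ccccc32)cc1` carries a different core, and the difference between the core of compound 1 and the core of compound 3 is not broken down here. In this assay compound 3 gives 28900 nM. Compound 4 `COc1ccc(Cn2cc(/C=C(\C#N)C(=O)c3c[nH]c4cc(F)ccc34)c3ccccc32)cc1` has not yet been measured; it differs from compound 3 by fluoro in place of methoxy on an aromatic carbon, the same change at the same place as from compound 1 to compound 2. Since that single earlier instance gave a 6.6-fold higher number from compound 1 to compound 2 (0.82 log units; beyond the scatter), compound 4 is expected to give a weaker result, a 4.2-fold higher number from compound 3 to compound 4 (0.62 log units; beyond the scatter), although the precedent comes from a different core. Compound 4 is therefore estimated at 120000 nM, spanning 40000 nM to 350000 nM.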

Compound 4, half-maximal inhibitory concentration: 36300 nM
Beside the measured number, compound 4's estimate is 3.3-fold (0.52 log units) above it, outside the stated range (below it).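

In this assay, fluoro in place of methoxy gave a 1.3-fold higher number from compound 3 to compound 4 (0.10 log units; within the scatter), so on the core of compound 3 the change did not show the size it had on the core of compound 1. The two instances differ in size: the same change on two cores in this assay, a 6.6-fold higher number (0.82 log units; beyond the scatter) from compound 1 to compound 2 and a 1.3-fold higher number (0.10 log units; within the scatter) from compound 3 to compound 4, 5.2-fold (0.72 log units) apart, beyond the scatter of two such steps. This shows that, in this series, the step seen on one core did not carry over in size to the other, but two pairs do not show what in the cores sets the gap, or how the change would behave on a further core.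

Only methoxy and fluoro appear at this place on the two cores. Going by these compounds, what an amine, a chloro group or a carboxylic acid would give there remains open.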